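The source may report more compounds than this note shows. Statements on the series, on what has been measured and on what is new or still open speak of the compounds shown alone.

Three compounds built on the shared core of compound 3 `Cc1c(C(=O)/C=C/c2ccc(Cl)cc2)[n+]([O-])c2ccccc2[n+]1[O-]` have been tested in a functional assay on MOLT-4 cells (Homo sapiens) for inhibition, with a stated time of 3 days; a higher number here means a weaker inhibitor, a lower number a stronger inhibitor. Compound 3 gives 7750 nM, the lowest of the three numbers. Compound 1 `Cc1c(C(=O)/C=C/c2cccc([N+](=O)[O-])c2)[n+]([O-])c2ccccc2[n+]1[O-]` gives 16300 nM, and compound 2 `COc1ccc(/C=C/C(=O)c2c(C)[n+]([O-])c3ccccc3[n+]2[O-])cc1` gives 25800 nM. Within the data shown here, the only step that changes a single place among them is a 3.3-fold lower number from compound 2 to compound 3 (0.52 log units; beyond the scatter), showing that swapping one group at that spot can move the number modestly. Compound 4 `Cc1c(C(=O)/C=C/c2ccc(F)cc2)[n+]([O-])c2ccccc2[n+]1[O-]` differs from compound 3 by fluoro in place of chloro on an aromatic carbon. Among the measured compounds shown here, no measured pair exchanges these two halogens, so that step is only a loose guide. Both groups are single heavy atoms at the same place, so a step no larger than the scatter is expected, if anything toward a slightly higher number. Compound 4 is therefore expected at 10000 nM, within 4000 nM to 25000 nM. The expected step is a 1.3-fold higher number from compound 3 to compound 4 (0.11 log units; within the scatter).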

Compound 4, half-maximal inhibitory concentration: 6400 nM
Compound 4: the middle estimate sits 1.6-fold (0.19 log units) above what was measured; low and high end bracket the measured number.
By their numbers in this assay, from the lowest: compounds 4 and 3 (each within the scatter of the next); then compounds 1 and 2 (each within the scatter of the next).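

Fluoro in place of chloro gives a 1.2-fold lower number from compound 3 to compound 4 (0.08 log units; within the scatter) in this assay and so, at this spot on the ring, the two halogens cannot be told apart. Fluoro in place of methoxy gives a 4.0-fold lower number from compound 2 to compound 4 (0.61 log units; beyond the scatter) and so matches the earlier chloro step, which shows that the move away from methoxy is not special to chloro. No measurement at hand explains these steps.

Still open, as far as these compounds go, is how an amine or a carboxylic acid at this spot would compare with the two halogens, and whether bromo would match them too.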